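A few compounds are considered here, and "the series" means these few. Any claim that something is new, unique, unknown or untested is made for them only; others in the source may bear on it.

Compound 1, `C=CCN(CC=C)c1nc(C)nc(Nc2c(C)cc(C)cc2C)n1`, gives 115 nM in an assay on isolated protein for binding affinity to corticotropin-releasing factor receptor 1 (Homo sapiens); on this read-out lower numbers stand for stronger inhibition and higher numbers for weaker inhibition.
Compound 2, `C=CCN(CC=C)c1nc(C)nc(Nc2c(C)cccc2C)n1`, gives > 10000 nM in this assay.
Compound 3, `CCCN(CCC)c1nc(C)nc(Nc2c(C)cc(C)cc2C)n1`, gives 130 nM in this assay.

Compound 2 stands at the limit of > 10000 nM in this assay, at which 1 of the 3 values shown sits, which is a limit of the assay rather than a number. Compound 4, `CCCN(CC1CC1)c1nc(C)nc(Nc2c(C)cccc2C)n1`, differs from compound 2 by (cyclopropylmethyl)(propyl)amino in place of diallylamino on an aromatic carbon. Among the compounds with values here, the one measured step that bears on this kind of change is a 1.1-fold higher number from compound 1 to compound 3 (0.05 log units; within the scatter), where one amine replaced another on the same carbon. A change at this position is therefore expected to matter little, while an at least 86-fold higher number from compound 1 to compound 2 (1.93 log units; beyond the scatter) shows how far the weaker anilino group moves the number. For compound 4 the step that the limit leaves unreadable from compound 2 to compound 4 is expected to stay within the scatter. Compound 4 is estimated at 15000 nM, with a range from 4000 nM to 60000 nM.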

Compound 4, inhibition constant: > 10000 nM
Compound 4 was reported as a limit; the forecaster's own chance of this, stated with the estimate: 70%; the middle value is on the limit's open side.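

Compound 2 and compound 4 both give only a limit rather than a number, so no step between them can be read: the limit of > 10000 nM in this assay, at which 2 of the 4 values shown sit.

As far as these compounds go, whether (cyclopropylmethyl)(propyl)amino in place of diallylamino changes the value at all stays open.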